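The source may report more compounds than this note shows. Statements on the series, on what has been measured and on what is new or still open speak of the compounds shown alone.

Compound 1 `CC1CCCC(Oc2cccc3ccc(N)nc23)C1` gives 640 nM in an assay on cells with melanin-concentrating hormone receptor 1 (Homo sapiens) as the target, read by radioligand binding; a higher number here means a weaker inhibitor, a lower number a stronger inhibitor. Compound 2 `Nc1ccc2cccc(OCCC3CCCCC3)c2n1` gives 808 nM in this assay. Compound 3 `CC(C)OCCOc1cccc2ccc(N)nc12` gives only a limit of the assay, > 2000 nM in this assay.

Compound 3 therefore stands at the limit of > 2000 nM in this assay, at which 1 of the 3 values shown sits, the weakest end of what this assay reports, and no number is known for it. Compound 4 `CCOCC(C)Oc1cccc2ccc(N)nc12` differs from compound 3 by a group of 6 heavy atoms (5 carbon, 1 oxygen; no ring) in place of a group of 6 heavy atoms (5 carbon, 1 oxygen; no ring), on an oxygen on an aromatic ring. Among the compounds with values here, the only measured step that touches this part of the molecule is an at least 2.4-fold higher number from compound 2 to compound 3 (0.39 log units; beyond the scatter), which carried the value to the limit. Within the data shown here, no measured step speaks to a rearrangement within a chain of the same atoms, so no shift beyond the scatter is expected in this assay, that is a step that the limit leaves unreadable from compound 3 to compound 4. Compound 4 is estimated at 3000 nM, between 1200 nM and 8000 nM.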

Compound 4, half-maximal inhibitory concentration: 1070 nM
The estimate for compound 4 lay 2.8-fold (0.45 log units) above the measured number; the measured number lies below the stated range.
By their numbers in this assay, from the lowest: compounds 1, 2 and 4 (each within the scatter of the next). At a limit, above all of these: compound 3.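

With the same atoms joined differently on the oxygen on the aromatic ring, this assay shows an at least 1.8-fold lower number from compound 3 to compound 4 (0.27 log units; that floor lies within the scatter). This floor lies within the scatter, so the data do not establish that the rearrangement changes the value, although the new chain gives a measured number. The value for compound 3 remains a limit: the limit of > 2000 nM in this assay, at which 1 of the 4 values shown sits.

Going by these compounds, the true size of this step remains open, because only a floor is available. Also open, on these data alone, is how an amine or a carboxylic acid on this chain would read.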